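The compounds below may be only part of what the source reports. "The series", "measured", "known", "first", "only" and "open" are said of these compounds alone.

Compound 1 `Cc1nn2c(-c3nc4cc(Cl)ccc4[nH]3)c(-c3ccccc3)nc2s1`: 16900 nM
Compound 2 `Cc1nn2c(-c3nc4cc(Cl)c(F)cc4[nH]3)c(-c3ccc(F)cc3)nc2s1`: > 30000 nM
Compound 3 `Cc1ccc2[nH]c(-c3c(-c4ccc(F)cc4)nc4sc(C)nn34)nc2c1`: 11700 nM

These three compounds were tested in a functional assay on A549 cells (Homo sapiens) for antiproliferative activity, read by MTT assay; on this read-out higher numbers stand for weaker inhibition and lower numbers for stronger inhibition. The entry for compound 2, > 30000 nM, is a limit and not a number. Compound 3 gives 11700 nM, which lies within the usual scatter of compound 1 at 16900 nM.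

Compound 4 `Cc1nn2c(-c3nc4cc(Cl)ccc4[nH]3)c(-c3ccc(F)cc3)nc2s1` has chloro in place of methyl on an aromatic carbon. For the measured compounds named here, no measured pair shows this change alone, so in this assay no step beyond the scatter is expected. This expectation leans on compound 1, which also carries a chloro group and gives 16900 nM. The expected step is a 1.3-fold higher number from compound 3 to compound 4 (0.11 log units; within the scatter). For compound 4 the estimated value is 15000 nM, with an expected range from 7500 nM to 30000 nM.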

Compound 4, half-maximal inhibitory concentration: 10200 nM
For compound 4 the middle estimate is 1.5-fold (0.17 log units) above the measured one; measured number inside the range.
By their numbers in this assay, from the lowest: compounds 4, 3 and 1 (each within the scatter of the next). At a limit, above all of these: compound 2.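

In this assay, chloro in place of methyl on the aromatic carbon gives a 1.1-fold lower number from compound 3 to compound 4 (0.06 log units; within the scatter), and fluoro in place of hydrogen gives a 1.7-fold lower number from compound 1 to compound 4 (0.22 log units; within the scatter), so neither change separates the compounds. Hydrogen in place of fluoro at a different aromatic carbon gives the only step beyond the scatter, an at least 2.9-fold lower number from compound 2 to compound 4 (0.46 log units; beyond the scatter). The entry for compound 2 is a limit and not a number: the limit of > 30000 nM in this assay, at which 1 of the 4 values shown sits.

The compounds shown leave open whether an amine or a methoxy group at the chloro position would move the number beyond the scatter.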